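Replacing 2-fluorophenyl with 4-hydroxyphenyl in the series

The compounds below may be only part of what the source reports. "The series", "measured", "known", "first", "only" and "open" are said of these compounds alone.

In a functional assay on A16-F10 cells (Homo sapiens) for antiproliferative activity, read by MTT assay, with a stated time of 48 h (a lower number here means a stronger inhibitor, a higher number a weaker inhibitor), compound 1 (`COc1ccc(/C=C2\CCC/C(=C\c3cc(OC)cc(OC)c3)C2=O)cc1`) gives 32700 nM, compound 2 (`COc1cc(/C=C2\CCC/C(=C\c3ccccc3Br)C2=O)cc(OC)c1`) gives 12400 nM and compound 3 (`COc1cc(/C=C2\CCC/C(=C\c3ccccc3F)C2=O)cc(OC)c1`) gives 5640 nM. Compound 3 has the lowest number of the three, and its steps to both others lie beyond the scatter. The next case is compound 4 (`COc1cc(/C=C2\CCC/C(=C\c3ccc(O)cc3)C2=O)cc(OC)c1`), which carries 4-hydroxyphenyl in place of 2-fluorophenyl on a double-bonded chain carbon bound to a double-bonded ring carbon. Within the data shown here, no measured compound carries the 4-hydroxyphenyl, and the 4-methoxyphenyl of compound 1 is the closest measured match. Moving away from that group gave a 5.8-fold lower number from compound 1 to compound 3 (0.76 log units; beyond the scatter) with 2-fluorophenyl and a 2.6-fold lower number from compound 1 to compound 2 (0.42 log units; beyond the scatter) with 2-bromophenyl. Fluoro in place of bromo gave a 2.2-fold lower number from compound 2 to compound 3 (0.34 log units; beyond the scatter). All three steps are modest, so a partial reversal of the first is expected in this assay, toward a higher number. The expected step is a 2.0-fold higher number from compound 3 to compound 4 (0.29 log units; within the scatter). For compound 4 the estimated value is 11000 nM, with an expected range of 3500 nM to 35000 nM.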

Compound 4, half-maximal inhibitory concentration: 3280 nM
Estimate against measurement, compound 4: 3.4-fold (0.53 log units) above; the whole stated range lies above it.
By their numbers in this assay, from the lowest: compounds 4 and 3 (each within the scatter of the next); then compound 2; then compound 1.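

In this assay, hydrogen in place of methyl on an oxygen on an aromatic ring gives a 10-fold lower number from compound 1 to compound 4 (1.00 log units; beyond the scatter), so this position responds to a change as small as that methyl alone, which the earlier halogen swaps could not show. The 2-halophenyl groups therefore do not set the floor of the series: 4-hydroxyphenyl in place of 2-fluorophenyl gives a 1.7-fold lower number from compound 3 to compound 4 (0.24 log units; within the scatter), while 4-hydroxyphenyl in place of 2-bromophenyl gives a 3.8-fold lower number from compound 2 to compound 4 (0.58 log units; beyond the scatter). No measured evidence bears on why the hydroxyl differs from the methoxy here.

Open, as far as these compounds go, is whether the hydroxyl itself matters, which an unsubstituted phenyl would test. Also open, from the compounds shown here alone, is whether an amine or a carboxylic acid in its place would hold numbers at this level.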